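The source may report more compounds than this note shows. Statements on the series, on what has been measured and on what is new or still open speak of the compounds shown alone.

Measured compounds:
- compound 1, `CCN(CC)S(=O)(=O)c1ccc(S(=O)(=O)N2CCC[C@@H](C(=O)N3CCC(O)CC3)C2)cc1`: 870 nM
- compound 2, `CC(C)S(=O)(=O)c1ccc(S(=O)(=O)N2CCC[C@@H](C(=O)N3CCC(F)(F)CC3)C2)cc1`: 11 nM

Both were tested in a functional assay on MIA PaCa-2 cells (Homo sapiens) for inhibition, read by MTT assay, with a stated time of 7 days (on this read-out lower numbers stand for stronger inhibition and higher numbers for weaker inhibition), where compound 1 gives 870 nM and compound 2 gives 11 nM. Of the two numbers, compound 1 has the higher one, so it is the weaker inhibitor here; the gap to compound 2 is far beyond the usual scatter, but compound 2 differs from compound 1 in more than one place, so no single change can be credited for that difference.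

Compound 3, `CCN(CC)S(=O)(=O)c1ccc(S(=O)(=O)N2CCC[C@@H](C(=O)N3CCC(C(F)(F)F)CC3)C2)cc1`, has not yet been measured in this assay. It differs from compound 1 in one place only: trifluoromethyl in place of hydroxy on a saturated ring carbon. Nothing in the measured pair isolates this particular change, so the expectation rests on little. The step from compound 1 to compound 3 is expected to be a modest gain in inhibition, roughly a 3.5-fold lower number from compound 1 to compound 3 (0.54 log units; beyond the scatter), with a direction that is not certain. On that basis compound 3 is estimated at 250 nM, within a range from 60 nM to 1000 nM.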

Compound 3, half-maximal inhibitory concentration: 320 nM
Compound 3: the middle estimate sits 1.3-fold (0.11 log units) below what was measured; low and high end bracket the measured number.
By their numbers in this assay, from the lowest: compound 2; then compound 3; then compound 1.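

In this assay, within the data shown here, the change from 4-hydroxypiperidin-1-yl to 4-(trifluoromethyl)piperidin-1-yl gives (a 2.7-fold lower number from compound 1 to compound 3 (0.43 log units; beyond the scatter)), the first comparison here in which only one place differs, and it shows that this ring carbon, three ring bonds from the ring nitrogen, can alter the read-out while the rest of the molecule stays the same. The hydroxy group, with its hydrogen-bond donor and acceptor, is also not required for inhibition in these cells, since trifluoromethyl, which has neither, gives a modest gain rather than a loss. No measurement shown accounts for this gain, so the step stands as an observation without an explanation.

The compounds shown cannot tell whether the gain comes from removing hydroxy or from adding trifluoromethyl, a question that a plain hydrogen or a methyl group on the same ring carbon could help to settle, and an amine or a carboxylic acid there would test a different kind of group. Compound 2 differs from compound 3 in more than one place, so its lower number cannot be credited to any single feature.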